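Swapping Iodo for Methyl on Compound 2

The source may hold more compounds than are shown below. What is called first, only, known or untested is meant among the compounds shown, and "the series" means these compounds.

Compound 2 `O=C(CCCN1C(=O)c2ccccc2C1=O)Nc1ccc(Cl)cc1I` was tested in a functional assay on the whole organism (strain albino) with Mus musculus as the target, with a stated time of 0.5 h (on this read-out higher numbers stand for an effect only at larger amounts of compound and lower numbers for an effect already at smaller amounts), where compound 2 gives 100 mg/kg. Compound 1 `O=C(CCCN1C(=O)c2ccccc2C1=O)Nc1ccc(Cl)cc1` differs only by lacking the iodo group, and in this assay compound 1 gives 100 mg/kg; the step of no change at the digits printed from compound 1 to compound 2 (within the scatter) shows that adding iodo left the dose unchanged within the scatter. Compound 3 `Cc1cc(Cl)ccc1NC(=O)CCCN1C(=O)c2ccccc2C1=O` is the next variant: methyl in place of iodo on an aromatic carbon. For the measured compounds named here, only that one earlier step bears on this change, and it was flat, so no shift beyond the scatter is expected, no change at the digits printed from compound 2 to compound 3 (within the scatter). Compound 3 is therefore estimated to need 100 mg/kg, with a range from 50 mg/kg to 300 mg/kg.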

Compound 3, minimum effective dose: 300 mg/kg
Compound 3: middle estimate off by 3.0-fold (0.48 log units), on the low side; the range from low to high includes it.
By their numbers in this assay, from the lowest: compounds 1 and 2 (each within the scatter of the next); then compound 3.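

This position turns out not to be indifferent to its substituent: in this assay methyl in place of iodo gives a 3.0-fold higher number from compound 2 to compound 3 (0.48 log units; beyond the scatter) and methyl in place of hydrogen gives a 3.0-fold higher number from compound 1 to compound 3 (0.48 log units; beyond the scatter) on the same ring carbon. Iodo and hydrogen had stood level, so the earlier pair gave no sign that a group here could matter. Nothing measured here accounts for methyl behaving differently from both. Still open, from the compounds shown here alone, is whether this shift is particular to methyl: an amine, a methoxy group or a longer chain such as ethyl at this place would test that.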